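Swapping the styryl arm for a methoxyphenoxy on a shared core

The source may hold more compounds than are shown below. What is called first, only, known or untested is meant among the compounds shown, and "the series" means these compounds.

Measured compounds:
- compound 1, `Cc1ccccc1-n1nc(C)c2c1NC(=O)[C@H](C)S[C@@H]2c1ccc(/C=C/c2ccccc2)cc1`: "not active" (no number reported) in an assay on isolated protein for agonist activity at Bile acid receptor (Homo sapiens), read by AlphaScreen, with a stated time of 30 min; a higher number here means that more compound is needed for the effect, a lower number that less compound is needed
- compound 2, `Cc1nn(-c2ccccc2Cl)c2c1C(c1ccc(Oc3ccccc3)cc1)SC(C)C(=O)N2`: 2700 nM in this assay
- compound 3, `Cc1cccc(-n2nc(C)c3c2NC(=O)[C@H](C)S[C@@H]3c2ccc(Oc3ccccc3)cc2)c1`: 2400 nM in this assay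

Compound 1 carries a 2-phenylethenyl group on its outer aromatic ring and is reported only as "not active" (no number reported) in this assay, with no number attached, so it stands outside the range that compound 2 and compound 3 occupy. Those two, which both carry a phenoxy group in that place, give numbers close to one another in this assay: compound 2 gives 2700 nM and compound 3 gives 2400 nM.

Compound 4, `COc1ccccc1Oc1ccc([C@H]2S[C@@H](C)C(=O)Nc3c2c(C)nn3-c2ccccc2C)cc1`, is the as yet unmeasured analogue of compound 1 with the change (2-methoxyphenoxy in place of 2-phenylethenyl on an aromatic carbon). Going by the values given here, no step between measured compounds covers this change, so the expectation rests on the phenoxy pair: compound 4 is expected to move from the inactive side toward the range of compound 2 and compound 3, a gain well beyond the scatter if a number appears at all.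

Compound 4 is estimated at 2500 nM in this assay, with a range of 700 nM to 9000 nM.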

Compound 4, half-maximal effective concentration: 1700 nM
Estimate against measurement, compound 4: 1.5-fold (0.17 log units) above; low and high end bracket the measured number.
By their numbers in this assay, from the lowest: compounds 4, 3 and 2 (each within the scatter of the next).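

In this assay, going by these compounds alone, compound 1 gives "not active" (no number reported) and compound 4 gives 1700 nM so no step between the two can be read. No measurement shown here bears on this result. The compounds shown leave open how 2-methoxyphenoxy compares with plain phenoxy on an otherwise identical core.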